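Cytotoxicity notes on the bicyclic amine series

The source may report more compounds than this note shows. Statements on the series, on what has been measured and on what is new or still open speak of the compounds shown alone.

Measured so far in an ADME assay on MDCK cells (Canis lupus familiaris) for cytotoxicity, read by microscopy, with a stated time of 48 h; on this read-out higher numbers stand for lower toxicity in this test and lower numbers for higher toxicity in this test:
compound 1 `Cc1ccsc1CN[C@@H]1C[C@H]2C[C@@H]([C@H]1C)C2(C)C`: 10000 nM
compound 2 `C[C@H]1[C@H](NCc2cnccn2)C[C@H]2C[C@@H]1C2(C)C`: the value is a limit of the assay, > 100000 nM
compound 3 `C[C@H]1[C@H](NCc2sccc2-c2ccsc2)C[C@H]2C[C@@H]1C2(C)C`: 12500 nM

Compound 3 gives the highest of the two plain numbers in this assay; its nearest neighbour is compound 1, and the step of a 1.3-fold higher number from compound 1 to compound 3 (0.10 log units; within the scatter) lies within the scatter. For the measured compounds named here, the one further value, that of compound 2, is a limit of > 100000 nM in this assay, at which 1 of the 3 values shown sits, and not a number.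

Compound 4 `C[C@H]1[C@H](NCc2sccc2Br)C[C@H]2C[C@@H]1C2(C)C` differs from compound 3 at one place: bromo in place of thiophen-3-yl on an aromatic carbon.

The step that bears most directly on this change is a 1.3-fold higher number from compound 1 to compound 3 (0.10 log units; within the scatter), where a small group on the same aromatic carbon gave way to the thiophen-3-yl without any shift beyond the scatter. The step of an at least 10-fold higher number from compound 1 to compound 2 (1.00 log units; beyond the scatter) replaces the whole aromatic ring and is not comparable. A bromo at the same carbon is therefore expected to leave this assay essentially unchanged, with the step of a 1.1-fold lower number from compound 3 to compound 4 (0.06 log units; within the scatter) expected to remain within the scatter. Compound 4 is estimated at 11000 nM, with a range of 4000 nM to 35000 nM.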

Compound 4, minimum cytotoxic concentration: 50000 nM
Beside the measured number, compound 4's estimate is 4.5-fold (0.66 log units) below it; the whole stated range lies below it.
By their numbers in this assay, from the lowest: compounds 1 and 3 (each within the scatter of the next); then compound 4. At a limit, above all of these: compound 2.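

At this aromatic carbon the group can matter in this assay: bromo gives a 4.0-fold higher number from compound 3 to compound 4 (0.60 log units; beyond the scatter) and a 5.0-fold higher number from compound 1 to compound 4 (0.70 log units; beyond the scatter), whereas methyl and thiophen-3-yl had given numbers within the scatter of each other, so the earlier flat step does not hold for every group here. From the compounds shown here alone, the comparison with the pyrazin-2-yl compound gives only a floor, an at least 2.0-fold lower number from compound 2 to compound 4 (0.30 log units; that floor lies within the scatter), so the size of that gap stays open. Nothing shown gives a cause for the step to bromo.

Open, going by these compounds, is whether other small groups on this carbon, such as chloro, methoxy or a nitrile, would track bromo or stay with methyl and thiophen-3-yl. Also open, on these data alone, is whether the step to bromo would carry over to a ring other than this sulfur-containing one.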